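The compounds below may be only part of what the source reports. "The series", "measured", "known", "first", "only" and "open" are said of these compounds alone.

Compound 1, `COc1ccc(-c2cc(/C=C/C(=O)c3ccc(N)cc3)[nH]n2)cc1`, gives -27% in a functional assay on CCRF-CEM cells (Homo sapiens) for cytotoxicity, read by sulforhodamine B assay, with a stated time of 48 h, tested at 10 uM; a higher number here means a weaker effect of the compound at the concentration tested, a lower number a stronger effect. Compound 2, `COc1ccc(C(=O)/C=C/c2cc(-c3cc(OC)c(OC)c(OC)c3)n[nH]2)cc1OC`, gives -26% in this assay. Compound 3, `COc1ccc(-c2cc(/C=C/C(=O)c3ccc(N)cc3)[nH]n2)cc1OC`, gives -8% in this assay.

Compound 3 differs from compound 1 by methoxy in place of hydrogen on an aromatic carbon, and this change gives a number 19 percentage points higher from compound 1 to compound 3 (beyond the scatter). The difference between the cores of compound 1 and compound 2 is not broken down here. Compound 4, `COc1cc(C(=O)/C=C/c2cc(-c3cc(OC)c(OC)c(OC)c3)n[nH]2)cc(OC)c1OC`, differs from compound 2 by methoxy in place of hydrogen on an aromatic carbon; the same kind of change occurs twice among the compounds shown, though the place in compound 4 is also meta to a methoxy group. Because compound 1 to compound 3 gave a number 19 percentage points higher from compound 1 to compound 3 (beyond the scatter), a step of similar size is expected here, namely a number 16 percentage points higher from compound 2 to compound 4 (beyond the scatter). Compound 4 is therefore estimated at -10% in this assay, likely between -35% and 15%.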

Compound 4, a percentage reported as activity, at one concentration (the size of the read-out at that concentration, not a potency): -7%
Estimate against measurement, compound 4: 3 percentage points below, within the range that was stated.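

In this assay, methoxy in place of hydrogen on an aromatic carbon gives a number 19 percentage points higher from compound 2 to compound 4 (beyond the scatter) and so repeats the earlier step on a different core: the same change on two cores in this assay, a number 19 percentage points higher (beyond the scatter) from compound 1 to compound 3 and a number 19 percentage points higher (beyond the scatter) from compound 2 to compound 4, 0 percentage points apart, within the scatter of two such steps. In these two pairs the change carries over from one core to the other, moving the number in the same direction and towards a weaker effect at the concentration tested. Two pairs cannot show that the step would hold on a further core, and a read-out at one concentration is not a potency.

The compounds shown leave open whether another group at that place, such as a hydroxyl, a fluorine or an ethoxy group, would move the number in the same way.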